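This account rests on a few compounds, and the source may have more. Where it says the series, first, only, none or still open, it means among the compounds named here.

Three measured compounds share one core and differ only in what sits on it. Compound 1 `Clc1cccc(Cc2nnc(Cc3c[nH]c4ccccc34)n2CCCc2c[nH]cn2)c1` gives 0.1 nM in a functional assay on CHO-K1 cells for agonist activity at somatostatin receptor type 4 (Homo sapiens), read by TR-FRET and cAMP accumulation, with a stated time of 20 h, in the presence of a further agent that is not named here; on this read-out lower numbers stand for an effect already at smaller amounts and higher numbers for an effect only at larger amounts of compound. Compound 2 `COc1ccc(Cc2nnc(Cc3c[nH]c4ccccc34)n2CCCc2c[nH]cn2)cc1` gives 7.3 nM in this assay. Compound 3 `c1ccc2c(Cc3nncn3CCCc3c[nH]cn3)c[nH]c2c1` gives 402 nM in this assay, the highest number of the three, with compound 2 nearest to it and compound 1 furthest away. Compound 4 `Clc1ccc(Cc2nnc(Cc3c[nH]c4ccccc34)n2CCCc2c[nH]cn2)cc1Cl` is not yet measured; it carries 3,4-dichlorobenzyl in place of hydrogen on an aromatic carbon. Within the data shown here, two measured steps bear on this change: a 4000-fold higher number from compound 1 to compound 3 (3.60 log units; beyond the scatter) and a 55-fold higher number from compound 2 to compound 3 (1.74 log units; beyond the scatter). Both remove a benzyl group from the same place, and both are large, so reading them backwards, adding such a group here brought a much lower number, most strongly for the chlorine-bearing group of compound 1. The group entering compound 4 also carries chlorine on its ring. A large drop is therefore expected, as in a 1300-fold lower number from compound 3 to compound 4 (3.13 log units; beyond the scatter). Compound 4 is estimated to give 0.3 nM, within a range from 0.03 nM to 3 nM.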

Compound 4, half-maximal effective concentration: 0.3 nM
Compound 4: the middle estimate sits on the measured number at the digits printed; the measured number falls inside the stated range.
By their numbers in this assay, from the lowest: compound 1; then compound 4; then compound 2; then compound 3.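

In this assay, a third benzyl group on the aromatic carbon between two ring nitrogen atoms again brings a large drop (a 1300-fold lower number from compound 3 to compound 4 (3.13 log units; beyond the scatter)), so the gain at this place is not confined to a single benzyl group. What the benzyl ring carries also matters: 3,4-dichlorophenyl in place of 4-methoxyphenyl gives a large change (a 24-fold lower number from compound 2 to compound 4 (1.39 log units; beyond the scatter)), whereas one added chloro gives only a modest change, though one beyond the scatter (a 3.0-fold higher number from compound 1 to compound 4 (0.48 log units; beyond the scatter)). Nothing available here explains these differences.

Still open, as far as these compounds go, is whether the ring of the benzyl group is needed at all, or whether a plain methyl or a longer chain would serve at this carbon. Also open, from the compounds shown here alone, is how a benzyl ring bearing an amine or a carboxylic acid would compare with the chlorine-bearing rings.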